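The compounds below may be only part of what the source reports. "The series", "measured", "known", "first", "only" and "open" are said of these compounds alone.

Measured compounds:
- compound 1 `S=C(N/N=C\c1ccc(Cl)cc1)N(Cc1ccccc1)Cc1ccccc1` — 159000 nM
- compound 2 `C=CCN(CC=C)C(=S)N/N=C\c1ccc([N+](=O)[O-])o1` — < 213000 nM

In an ADME assay on Vero cells (Chlorocebus sabaeus) for cytotoxicity, read by MTT assay, with a stated time of 72 h (on this read-out higher numbers stand for lower toxicity in this test and lower numbers for higher toxicity in this test), compound 1 gives 159000 nM, and this is the only plain number shown for the series. Among the compounds with values here, for compound 2 the read-out is a limit of this assay, < 213000 nM, not a number; the one piece of evidence on this point is the limit of < 213000 nM in this assay, at which 1 of the 2 values shown sits. Within the data shown here, no two measured compounds differ in a single place, so no measured step is available to anchor the next change.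

Compound 3 `C/C(=N/NC(=S)N(Cc1ccccc1)Cc1ccccc1)c1ccccc1` is not yet measured. It differs from compound 1 in one place: a group of 9 heavy atoms (8 carbon, 1 nitrogen; one six-membered aromatic ring of carbon only) in place of a group of 9 heavy atoms (7 carbon, 1 nitrogen, 1 chlorine; one six-membered aromatic ring of carbon only), on an amide-type nitrogen. The exchange swaps a group of nine heavy atoms carrying a chlorine for a group of nine heavy atoms without it, on an amide-type nitrogen whose other neighbour is the thiocarbonyl carbon.

With no measured step of this kind in hand, the expectation is that compound 3 stays close to compound 1 in this assay, with a step of a 1.1-fold lower number from compound 1 to compound 3 (0.03 log units; within the scatter) of no clear direction and not beyond the usual scatter. The estimate for compound 3 is therefore 150000 nM, within a range from 60000 nM to 350000 nM.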

Compound 3, half-maximal cytotoxic concentration: 167000 nM
For compound 3 the middle estimate is 1.1-fold (0.05 log units) below the measured one; the range from low to high includes it.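

In this assay, within the data shown here, the first single-place step reads a 1.1-fold higher number from compound 1 to compound 3 (0.02 log units; within the scatter), so compound 1 and compound 3 cannot be told apart in this test. On the amide-type nitrogen whose other neighbour is the thiocarbonyl carbon, the group of 9 heavy atoms carrying a chlorine can therefore give way to the group of 9 heavy atoms with 8 carbon, 1 nitrogen and no chlorine, with the read-out staying within the scatter; for this pair, the chlorine is not needed to hold the value at this level. The one limit shown in the series has no bearing on this pair, so nothing shown accounts for the step.

Among these compounds, compound 2 gives < 213000 nM in this assay, which is a limit of the assay and not a number, and it differs from the other compounds in more than one place, so it adds no step. As far as these compounds go, it remains open whether this flat result holds for very different groups at the same place, such as one carrying a primary amine or a carboxylic acid, or one with a longer chain.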